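The compounds below may be only part of what the source reports. "The series", "measured", "known", "first", "only" and "open" are said of these compounds alone.

Measured compounds in a functional assay on SGC-7901 cells (Homo sapiens) for cytotoxicity, read by MTT assay, with a stated time of 48 h; a lower number here means a stronger inhibitor, a higher number a weaker inhibitor:

Compound 1 `O=c1ccoc2cc(OCc3cn(Cc4ccccc4Br)nn3)ccc12` — compound 1 gives > 100000 nM, which is a limit of this assay and not a number.
Compound 2 `O=c1ccoc2cc(OCc3cn(Cc4ccccc4Cl)nn3)ccc12` — compound 2 gives > 100000 nM, also a limit.
Compound 3 `O=c1ccoc2cc(OCc3cn(Cc4ccccc4)nn3)ccc12` — compound 3 gives > 100000 nM, also a limit.

Compound 1 stands at the limit of this assay, as do the other two measured compounds (the limit of > 100000 nM in this assay, at which 3 of the 3 values shown sit). The steps from compound 1 to compound 2 a step that the two limits leave unreadable from compound 1 to compound 2, from compound 1 to compound 3 a step that the two limits leave unreadable from compound 1 to compound 3 and from compound 2 to compound 3 a step that the two limits leave unreadable from compound 2 to compound 3 therefore cannot be sized; none of the three halogen or hydrogen variants on the benzyl group reached a readable value.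

Compound 4 `N#Cc1cccc(Cn2cc(COc3ccc4c(=O)ccoc4c3)nn2)c1` is not yet measured. The change from compound 1 is 3-cyanophenyl in place of 2-bromophenyl on a saturated chain carbon bound to an aromatic nitrogen. Within the data shown here, the only measured steps, all among compounds 1, 2 and 3, bear on it by showing that changes on this ring have so far left every value at the limit. No direction can be read from them. The expectation for compound 4 is a step of a number no higher from compound 1 to compound 4 (the limit leaves the size open), that is, no readable step beyond the scatter. Compound 4 is expected at about 100000 nM, in the range 30000 nM to 300000 nM, most likely again reported as a limit.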

Compound 4, half-maximal inhibitory concentration: > 100000 nM
Compound 4: no number, only a limit (the forecaster's own chance of this, stated with the estimate: 80%); the middle value lies on the limit itself.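

Among these compounds, compound 4 also stays at a limit in this assay, so no step to compound 4 from compound 1, compound 2 or compound 3 can be read: the limit of > 100000 nM in this assay, at which 4 of the 4 values shown sit. The compounds shown leave open whether any change on the benzyl group gives a readable value in this assay.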